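The compounds below may be only part of what the source reports. "The series", "measured", "known", "first", "only" and "open" are said of these compounds alone.

Three compounds share one core and differ only in the group on the aromatic oxygen. Compound 1 `CC(C)COc1ccc2c(Cl)ccnc2c1` gives 3030 nM in a functional assay on BGC-823 cells (Homo sapiens) for cytotoxicity, read by MTT assay, with a stated time of 48 h (on this read-out lower numbers stand for stronger inhibition and higher numbers for weaker inhibition), compound 2 `CC(C)Oc1ccc2c(Cl)ccnc2c1` gives 2630 nM, and compound 3 `CCCCOc1ccc2c(Cl)ccnc2c1` gives 3610 nM. Compound 3 thus holds the nominally highest number of the three, yet a 1.2-fold higher number from compound 1 to compound 3 (0.08 log units; within the scatter) and a 1.4-fold higher number from compound 2 to compound 3 (0.14 log units; within the scatter) both stay within the scatter, as does a 1.2-fold lower number from compound 1 to compound 2 (0.06 log units; within the scatter). Compound 4 `C=CCOc1ccc2c(Cl)ccnc2c1` carries vinyl in place of propyl on a saturated chain carbon bound to an oxygen on an aromatic ring. Among the measured compounds shown here, the steps that bear on this change, propyl or butyl against isopropyl, were all within the scatter, so no step beyond the scatter is expected in this assay from compound 3 to compound 4, with the estimate a 1.1-fold lower number from compound 3 to compound 4 (0.05 log units; within the scatter). Compound 4 is therefore expected to give about 3200 nM, between 1600 nM and 6400 nM.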

Compound 4, half-maximal inhibitory concentration: 2930 nM
Compound 4: middle estimate off by 1.1-fold (0.04 log units), on the high side, within the range that was stated.
By their numbers in this assay, from the lowest: compounds 2, 4, 1 and 3 (each within the scatter of the next).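

In this assay, replacing a saturated chain with allyl on an oxygen on an aromatic ring gives no step beyond the scatter against any of the three earlier compounds (a 1.2-fold lower number from compound 3 to compound 4 (0.09 log units; within the scatter); a 1.1-fold higher number from compound 2 to compound 4 (0.05 log units; within the scatter); a 1.0-fold lower number from compound 1 to compound 4 (0.01 log units; within the scatter)). The earlier compounds shown here carried only saturated chains, whereas this series now includes a double bond outside aromatic rings without a step beyond the scatter. No available evidence explains this result.

On these data alone, it remains open whether a benzyl group, a longer chain, an amine or a carboxylic acid on this oxygen would produce a step beyond the scatter.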